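Swapping an iodophenyl for a naphthyl sulfonamide

The compounds below may be only part of what the source reports. "The series", "measured", "known", "first", "only" and "open" are said of these compounds alone.

Compound 1 `COc1cc2nc(N3CCN(S(=O)(=O)c4ccc(I)cc4)CC3)nc(N)c2cc1OC` carries a 4-iodophenyl group on its sulfonyl sulfur. Within the data shown here, in a functional assay on PC-3 cells (Homo sapiens) for inhibition (a higher number here means a weaker inhibitor, a lower number a stronger inhibitor), compound 1 gives 15000 nM, the lowest of the two numbers measured so far. Among the measured compounds shown here, its only measured relative is compound 2 `COc1cc2nc(N3CCN(S(=O)(=O)c4ccc([N+](=O)[O-])cc4)CC3)nc(N)c2cc1OC`, which in this assay gives 36000 nM; the change of nitro in place of iodo on an aromatic carbon produced a 2.4-fold higher number from compound 1 to compound 2 (0.38 log units; beyond the scatter). Compound 3 `COc1cc2nc(N3CCN(S(=O)(=O)c4cccc5ccccc45)CC3)nc(N)c2cc1OC` differs from compound 1 in a single place: naphthalen-1-yl in place of 4-iodophenyl on a sulfonyl sulfur. For the measured compounds named here, no measured step bears directly on this change; the one step seen exchanges a substituent on the same ring rather than the ring itself, and it was modest. Compound 3 is therefore expected to stay close to compound 1 at 15000 nM, with an estimated step of no change at the digits printed from compound 1 to compound 3 (within the scatter), though the uncertainty is wide. The estimate for compound 3 is 15000 nM, within a range from 5000 nM to 50000 nM.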

Compound 3, half-maximal inhibitory concentration: 14000 nM
For compound 3 the middle estimate is 1.1-fold (0.03 log units) above the measured one; the measured number falls inside the stated range.
By their numbers in this assay, from the lowest: compounds 3 and 1 (each within the scatter of the next); then compound 2.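

In this assay, naphthalen-1-yl, with its two aromatic rings of carbon only, takes the place of the single-ring 4-iodophenyl on the sulfonyl sulfur with a 1.1-fold lower number from compound 1 to compound 3 (0.03 log units; within the scatter), so for this pair the larger group and the loss of iodine leave the number unchanged within the scatter. The earlier step changed only a substituent on the ring, whereas this one replaces the ring itself, and a 2.6-fold lower number from compound 2 to compound 3 (0.41 log units; beyond the scatter) places compound 2, with its 4-nitrophenyl group, apart from both compound 1 and compound 3. No measurement available here explains these numbers.

On these data alone, it remains open how a group without an aromatic ring, such as cyclohexyl, would behave on the sulfonyl sulfur. A phenyl ring carrying an amine or a carboxylic acid is equally untested among the compounds shown.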